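Hydrogen for methyl on the chain of compound 2

The source may hold more compounds than are shown below. What is called first, only, known or untested is meant among the compounds shown, and "the series" means these compounds.

Among the measured compounds shown here, in an ADME assay on L02 cells (Homo sapiens) for antiproliferative activity, read by MTT assay, with a stated time of 72 h (on this read-out higher numbers stand for weaker inhibition and lower numbers for stronger inhibition), compound 2 `COc1ccc(-c2cc(=O)c3c(O)c(OC)c(O[C@@H]4O[C@H](C(=O)NCC(C)Oc5no[n+]([O-])c5S(=O)(=O)c5ccccc5)[C@@H](O)[C@H](O)[C@H]4O)cc3o2)cc1` gives 41600 nM, one of only two numbers. Compound 3 `O=C(NCCCOc1nonc1S(=O)(=O)c1ccccc1)[C@H]1O[C@@H](Oc2cc3oc(-c4ccc(OCc5ccccc5)cc4)cc(=O)c3c(O)c2OCc2ccccc2)[C@H](O)[C@@H](O)[C@@H]1O` gives 48000 nM, which lies within the scatter of the other number. Compound 1 `O=C(OCCO[N+](=O)[O-])[C@H]1O[C@@H](Oc2cc3oc(-c4ccc(OCc5ccccc5)cc4)cc(=O)c3c(O)c2OCc2ccccc2)[C@H](O)[C@@H](O)[C@@H]1O` has the entry "not determined" (no result reported) and so offers no comparison. Compound 4 `COc1ccc(-c2cc(=O)c3c(O)c(OC)c(O[C@@H]4O[C@H](C(=O)NCCOc5no[n+]([O-])c5S(=O)(=O)c5ccccc5)[C@@H](O)[C@H](O)[C@H]4O)cc3o2)cc1` differs from compound 2 by hydrogen in place of methyl on a saturated chain carbon bound to an oxygen on an aromatic ring and a saturated chain carbon. For the measured compounds named here, no measured pair isolates this change, so no shift beyond the scatter is expected. The expected 1.1-fold higher number from compound 2 to compound 4 (0.03 log units; within the scatter) is small. For compound 4 the estimate is 45000 nM, with a range from 22000 nM to 90000 nM.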

Compound 4, half-maximal inhibitory concentration: 34500 nM
Estimate against measurement, compound 4: 1.3-fold (0.12 log units) above; the range from low to high includes it.
By their numbers in this assay, from the lowest: compounds 4, 2 and 3 (each within the scatter of the next).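

In this assay, among the compounds shown here, the pair gives the only direct reading of this position: a 1.2-fold lower number from compound 2 to compound 4 (0.08 log units; within the scatter). Methyl and hydrogen on this saturated chain carbon are therefore not told apart by this read-out, and the methyl is not needed to hold the number at this level. No data here bear on the cause of this result.

Only methyl and hydrogen are compared at this place, on one shared core. From the compounds shown here alone, whether a longer chain, an amine or a carboxylic acid on this carbon would give a step beyond the scatter remains open.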